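The compounds below may be only part of what the source reports. "The series", "measured", "known", "first", "only" and "open" are said of these compounds alone.

Working notes on the series in an assay on CHO cells for displacement of a labelled ligand from adenosine receptor A1 (Homo sapiens); a lower number here means a stronger inhibitor, a higher number a weaker inhibitor.

Compound 1 `CCCn1c(Br)nc2c(N)nc(NCCCc3ccccc3)nc21` gives 583 nM in this assay. Compound 2 `CCCn1c(-c2ccco2)nc2c(N)nc(NCCCc3ccccc3)nc21` gives 230 nM; the change from compound 1 to compound 2 is furan-2-yl in place of bromo on an aromatic carbon, and the step it made is a 2.5-fold lower number from compound 1 to compound 2 (0.40 log units; beyond the scatter). Compound 3 `CCCn1c(Br)nc2c(NCc3ccccc3)ncnc21` gives 5620 nM, the highest number of the three measured; the difference between the core of compound 3 and the core of compound 1 is not broken down here. Compound 4 `CCCn1c(-c2ccco2)nc2c(NCc3ccccc3)ncnc21` is not yet measured in this assay. From compound 3 to compound 4 the change is furan-2-yl in place of bromo on an aromatic carbon, the same change as from compound 1 to compound 2. For the measured compounds named here, a step of similar size is expected, a 2.4-fold lower number from compound 3 to compound 4 (0.39 log units; beyond the scatter), resting on the one earlier instance, a 2.5-fold lower number from compound 1 to compound 2 (0.40 log units; beyond the scatter). For compound 4 the estimate is 2300 nM, expected between 1000 nM and 5000 nM.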

Compound 4, inhibition constant: 546 nM
Beside the measured number, compound 4's estimate is 4.2-fold (0.62 log units) above it, outside the stated range (below it).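

In this assay, furan-2-yl in place of bromo again lowers the number, with a 10-fold lower number from compound 3 to compound 4 (1.01 log units; beyond the scatter), so the direction of the change carries over from the core of compound 1 to the core of compound 3. The size of the step does not carry over, and the two steps differ: the same change on two cores in this assay, a 2.5-fold lower number (0.40 log units; beyond the scatter) from compound 1 to compound 2 and a 10-fold lower number (1.01 log units; beyond the scatter) from compound 3 to compound 4, 4.1-fold (0.61 log units) apart, beyond the scatter of two such steps. With only these two pairs, the notes do not show which difference between the two cores goes with the larger step, or what size the step would take on a further core.

On these data alone, whether an amine or a phenyl ring in place of bromo on this aromatic carbon would give a similar step stays open. Also open, as far as these compounds go, is whether a longer chain in place of the propyl group would alter the size of the furan-2-yl step.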